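The compounds below may be only part of what the source reports. "The series", "measured", "known", "first", "only" and "open" are said of these compounds alone.

Compound 3 `FC(F)(F)c1ccc(CSc2nc(Nc3ccc(Cl)cc3)c3ccccc3n2)cc1` shares its core with compound 2 `FC(F)(F)c1ccc(CSc2nc(Nc3cccc(C(F)(F)F)c3)c3ccccc3n2)cc1`, compound 1 `CCOc1ccccc1Nc1nc(SCc2ccc(C(F)(F)F)cc2)nc2ccccc12` and the still unmeasured compound 4 `Fc1ccc(Nc2nc(SCc3ccc(C(F)(F)F)cc3)nc3ccccc23)cc1Cl`. In a functional assay on MDA-MB-231 cells (Homo sapiens) for cytotoxicity, read by MTT assay, with a stated time of 72 h (a lower number here means a stronger inhibitor, a higher number a weaker inhibitor), compound 3 gives 15100 nM, the highest of the two numbers available. Compound 2 gives 11100 nM, and the step of a 1.4-fold higher number from compound 2 to compound 3 (0.13 log units; within the scatter) leaves the pair within the scatter. Compound 1 gives > 50000 nM, which is only a limit of the assay and not a number. From that limit the steps of an at least 4.5-fold lower number from compound 1 to compound 2 (0.65 log units; beyond the scatter) and an at least 3.3-fold lower number from compound 1 to compound 3 (0.51 log units; beyond the scatter) both run beyond the scatter. The change to compound 4 is 3-chloro-4-fluorophenyl in place of 4-chlorophenyl on a nitrogen on an aromatic ring, a smaller alteration on the nitrogen on an aromatic ring than the swap from compound 2 to compound 3. For compound 4 in this assay the expected step is therefore a 1.3-fold lower number from compound 3 to compound 4 (0.10 log units; within the scatter). Compound 4 is estimated at 12000 nM, between 5000 nM and 30000 nM.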

Compound 4, half-maximal inhibitory concentration: 14500 nM
The estimate for compound 4 lay 1.2-fold (0.08 log units) below the measured number; the range from low to high includes it.
By their numbers in this assay, from the lowest: compounds 2, 4 and 3 (each within the scatter of the next). At a limit, above all of these: compound 1.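

In this assay, a 1.0-fold lower number from compound 3 to compound 4 (0.02 log units; within the scatter) shows that 3-chloro-4-fluorophenyl on the nitrogen cannot be told apart from 4-chlorophenyl, and a 1.3-fold higher number from compound 2 to compound 4 (0.12 log units; within the scatter) shows the same against 3-(trifluoromethyl)phenyl. Only 2-ethoxyphenyl stands apart among the groups shown, with an at least 3.4-fold lower number from compound 1 to compound 4 (0.53 log units; beyond the scatter). The value of compound 1 is a limit of the assay and not a number: the limit of > 50000 nM in this assay, at which 1 of the 4 values shown sits.

The compounds shown leave open whether 4-ethoxyphenyl would go with 2-ethoxyphenyl or with the other three groups. They also leave open whether a carboxylic acid or an amine on this phenyl would shift the number beyond the scatter.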